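Aromatic ring exchange on the carbonyl carbon

This account rests on a few compounds, and the source may have more. Where it says the series, first, only, none or still open, it means among the compounds named here.

In a physicochemical assay for solubility, measured as kinetic solubility, with a stated time of 1 h, at pH 7.4 (a higher number here means a more soluble compound, a lower number a less soluble compound), compound 1 (`CC(=O)N[C@@H](C)C(=O)NC1=NN(c2ccc(Cl)c(Cl)c2)CC1`) gives 58000 nM and compound 2 (`O=C(NC1=NN(c2ccc(Cl)c(Cl)c2)CC1)c1cncnc1`) gives 8000 nM, the lower of the two numbers. Compound 3 (`O=C(NC1=NN(c2ccc(Cl)c(Cl)c2)CC1)c1ccncc1F`) differs from compound 2 at one place: 3-fluoropyridin-4-yl in place of pyrimidin-5-yl on a carbonyl carbon. Among the measured compounds shown here, the only measured step, a 7.3-fold lower number from compound 1 to compound 2 (0.86 log units; beyond the scatter), is modest but beyond the scatter. It bears only loosely, as no exchange of one aromatic ring for another at this place has been measured. The expected change is small and slightly downward: a 1.3-fold lower number from compound 2 to compound 3 (0.12 log units; within the scatter). Compound 3 is estimated at 6000 nM, with an expected range of 2000 nM to 20000 nM.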

Compound 3, solubility: 36000 nM
Compound 3: the middle estimate sits 6.0-fold (0.78 log units) below what was measured, outside the stated range (above it).
By their numbers in this assay, from the lowest: compound 2; then compounds 3 and 1 (each within the scatter of the next).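

In this assay, among the compounds shown here, the two aromatic rings are not interchangeable on this carbonyl carbon: a 4.5-fold higher number from compound 2 to compound 3 (0.65 log units; beyond the scatter), the first measured exchange of one such ring for another. An aromatic ring here also need not read below 1-acetamidoethyl, as a 1.6-fold lower number from compound 1 to compound 3 (0.21 log units; within the scatter), leaves those two compounds level, though compound 2 goes against this. No available measurement accounts for either step.

Open, from the compounds shown here alone, is whether the step from compound 2 to compound 3 follows the fluorine, which pyridin-4-yl without fluorine would test. Also open, going by these compounds, is how an amine or a carboxylic acid on the aromatic ring would read.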